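The source may report more compounds than this note shows. Statements on the series, on what has been measured and on what is new or still open speak of the compounds shown alone.

Measured so far in an assay on HEK293 cells for positive allosteric modulation of metabotropic glutamate receptor 5 (Homo sapiens), read by FLIPR; a lower number here means that less compound is needed, a higher number that more compound is needed for the effect:
- compound 1, `CC1CCC(C(=O)N2CC(c3nc(-c4cccc(Cl)c4)no3)C2)CC1`: 1500 nM
- compound 2, `Cc1ccc(S(=O)(=O)N2CC(c3nc(-c4cccc(Cl)c4)no3)C2)cc1`: > 10000 nM
- compound 3, `O=C(c1ccc(F)cc1)N1CC(c2nc(-c3cccc(Cl)c3)no2)C1`: > 10000 nM

Compound 3 stands at the limit: in this assay compound 3 gives > 10000 nM, which is a limit of the assay and not a number. Among the compounds with values here, the only step touching the carbonyl substituent is an at least 6.6-fold higher number from compound 1 to compound 3 (0.82 log units; beyond the scatter), which is beyond the scatter; it says only that 4-fluorophenyl gives a limit where 4-methylcyclohexyl gives a number. Compound 2 also sits at the limit, so the limit of > 10000 nM in this assay, at which 2 of the 3 values shown sit, describes most of the series.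

Compound 4, `O=C(c1ccccc1F)N1CC(c2nc(-c3cccc(Cl)c3)no2)C1`, differs from compound 3 by 2-fluorophenyl in place of 4-fluorophenyl on a carbonyl carbon. Within the data shown here, no measured step moves a fluorine within the phenyl ring, so nothing sets a size for this change. With compound 3 at the limit, compound 4 is expected to remain near or at the limit as well, with a number no higher from compound 3 to compound 4 (the limit leaves the size open) as the estimated step. For compound 4 the expected value in this assay is 10000 nM, within 3000 nM to 30000 nM.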

Compound 4, half-maximal effective concentration: > 10000 nM
Compound 4 ended at the assay's limit; the forecaster's own chance of this, stated with the estimate: 70%; the middle value sits exactly at the limit.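

With the fluorine on the other ring position, the carbonyl substituent still gives no number in this assay: compound 4 gives > 10000 nM, a limit of the assay and not a number. The step between compound 3 and compound 4 cannot be read, so the two fluorophenyl placements cannot be ranked against each other. Replacing 4-methylcyclohexyl with 2-fluorophenyl on the carbonyl carbon gives an at least 6.6-fold higher number from compound 1 to compound 4 (0.82 log units; beyond the scatter), a second amide step away from compound 1 that lies beyond the scatter, and the series now reads: the limit of > 10000 nM in this assay, at which 3 of the 4 values shown sit.

How far the 4-methylcyclohexyl group can be changed while a number remains is open, with compound 1 the only compound shown that gives one. Also open, as far as these compounds go, is how an unsubstituted cyclohexyl, a longer alkyl chain or an unsubstituted phenyl on the carbonyl carbon would read in this assay.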